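Swapping bromo for ethynyl on a shared quinazoline-type scaffold

The compounds below may be only part of what the source reports. "The series", "measured", "known", "first", "only" and "open" are said of these compounds alone.

Of the compounds shown here, three sharing a common core have been tested in a functional assay on CAL-27 cells (Homo sapiens) for cytotoxicity, read by resazurin assay; on this read-out lower numbers stand for stronger inhibition and higher numbers for weaker inhibition. Compound 1, `C#Cc1cccc(Nc2ncnc3ccc(S(=O)(=O)n4ccc(/C=C/C(=O)NO)c4)cc23)c1`, gives 160 nM. Compound 2, `Nc1ccccc1NC(=O)c1ccc(COc2ccc3ncnc(Nc4cccc(Br)c4)c3c2)cc1`, gives 620 nM. Compound 3, `C#Cc1cccc(Nc2ncnc3cc(NC(=O)c4ccc(C(=O)Nc5ccccc5N)nc4)ccc23)c1`, gives 450 nM. Among these three numbers compound 2 stands highest, which on this read-out means the weakest inhibition; compound 3 sits close to it, within the usual scatter, so no real order between the two can be claimed, whereas compound 1 lies beyond the scatter and is clearly more potent than compound 2.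

Compound 4, `C#Cc1cccc(Nc2ncnc3ccc(OCc4ccc(C(=O)Nc5ccccc5N)cc4)cc23)c1`, is not yet measured. It differs from compound 2 in a single place: ethynyl in place of bromo on an aromatic carbon. The rest of the molecule, including the benzyl ether linker and the benzamide bearing the aminophenyl group, is kept unchanged.

For the measured compounds named here, no pair of measured compounds differs in exactly this way, so the size of the step cannot be read from the data. Both compounds carrying ethynyl, compound 1 and compound 3, give lower numbers than compound 2, though they differ from it in more than one place. The expectation for compound 4 is a modest improvement in this assay, a step from compound 2 to compound 4 of a 1.6-fold lower number from compound 2 to compound 4 (0.19 log units; within the scatter), within or near the scatter. Compound 4 is therefore estimated at 400 nM, with a range from 150 nM to 1000 nM.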

Compound 4, half-maximal inhibitory concentration: 610 nM
The estimate for compound 4 lay 1.5-fold (0.18 log units) below the measured number, and the stated range covers the measured number.
By their numbers in this assay, from the lowest: compound 1; then compounds 3, 4 and 2 (each within the scatter of the next).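

Replacing the 3-bromophenyl group with a 3-ethynylphenyl group in this assay gives a 1.0-fold lower number from compound 2 to compound 4 (0.01 log units; within the scatter) and so, at this position on an aromatic carbon, meta to a large group, the two groups cannot be told apart. Compound 1 and compound 3 also carry ethynyl, but each differs from compound 2 in more than one place, so they could not show what ethynyl does on its own; this pair isolates that single change, and no effect beyond the scatter appears on this scaffold. Nothing measured here offers an explanation for this result.

The compounds shown leave open whether a different group in the same place, such as chlorine, an amine, a carboxylic acid or a longer chain like propynyl, would move the number beyond the scatter. They also leave open whether bromo and ethynyl would remain interchangeable with the other side of the molecule changed, as a bromo counterpart of compound 1 or of compound 3 would show.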